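The compounds below may be only part of what the source reports. "The series", "measured", "known", "first", "only" and "open" are said of these compounds alone.

Working notes on the series. Compound 1 `COc1nc2ccc(Br)cc2cc1C(c1ccccc1)n1cc(-c2ccc(Br)cc2)nn1` gives 7.43% in an ADME assay on PC-3 cells (Homo sapiens) for cytotoxicity, read by sulforhodamine B assay, with a stated time of 48 h, tested at 10 uM; a higher number here means more inhibition at the concentration tested (going by the name of the read-out), a lower number less inhibition. Compound 2 `COc1nc2ccc(Br)cc2cc1C(c1ccccc1)n1cc(CCCO)nn1` gives 14.7% in this assay; of the two numbers it is the higher, but only by the step of a number 7.3 percentage points higher from compound 1 to compound 2 (within the scatter), which is within the scatter. Compound 3 `CCCc1cn(C(c2ccccc2)c2cc3cc(Br)ccc3nc2OC)nn1` is not yet measured. It differs from compound 2 by hydrogen in place of hydroxy on a saturated chain carbon, three bonds along the chain from an aromatic carbon. For the measured compounds named here, the single measured step, a number 7.3 percentage points higher from compound 1 to compound 2 (within the scatter), concerns another place and is within the scatter, so the expected step of a number 4.7 percentage points lower from compound 2 to compound 3 (within the scatter) is none beyond the scatter. For compound 3 the estimated value in this assay is 10%, expected to lie between 0% and 25%.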

Compound 3, a percentage reported as inhibition, at one concentration (the size of the read-out at that concentration, not a potency): 8.3%
Beside the measured number, compound 3's estimate is 1.7 percentage points above it; measured number inside the range.
By their numbers in this assay, from the lowest: compounds 1, 3 and 2 (each within the scatter of the next).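

In this assay, hydrogen in place of hydroxy on this saturated chain carbon gives a number 6.4 percentage points lower from compound 2 to compound 3 (within the scatter), so at this position the hydroxy does not separate the two compounds. Propyl in place of 4-bromophenyl on an aromatic carbon gives a number 0.9 percentage points higher from compound 1 to compound 3 (within the scatter), so neither this chain nor the aryl group stands apart from the other here. No measurement is available that would explain these numbers. As far as these compounds go, whether an amine or a carboxylic acid in place of the hydroxy, or a longer chain, would give a step beyond the scatter remains open.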